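Compound 2 and its 4-chlorophenyl counterpart

The compounds below may be only part of what the source reports. "The series", "measured", "known", "first", "only" and "open" are said of these compounds alone.

Compound 1 `COc1cc(Nc2ncnc3c(NC(=O)Nc4cccc(Oc5ccccc5)c4)cccc23)cc(OC)c1`: 14000 nM
Compound 2 `COc1cc(Nc2ncnc3c(NC(=O)Nc4cc(Cl)c(Cl)cc4Cl)cccc23)cc(OC)c1`: 4890 nM
Compound 3 `COc1cc(Nc2ncnc3c(NC(=O)Nc4cccc(Cc5ccccc5)c4)cccc23)cc(OC)c1`: 1740 nM

In a functional assay on RT-112 cells (Homo sapiens) for antiproliferative activity, read by MTT assay, with a stated time of 72 h (on this read-out lower numbers stand for stronger inhibition of growth and higher numbers for weaker inhibition of growth), compound 2 gives 4890 nM, the middle of the three numbers, and its gaps to the other two lie beyond the scatter. Compound 4 `COc1cc(Nc2ncnc3c(NC(=O)Nc4ccc(Cl)cc4)cccc23)cc(OC)c1` has 4-chlorophenyl in place of 2,4,5-trichlorophenyl on an amide-type nitrogen. For the measured compounds named here, no measured step makes this change. The only one available, an 8.0-fold lower number from compound 1 to compound 3 (0.91 log units; beyond the scatter), swaps phenoxy for benzyl on an aromatic carbon. It shows that a single change of group can move the number, but it gives no direction here. The expected change is therefore small: a 1.2-fold lower number from compound 2 to compound 4 (0.09 log units; within the scatter). For compound 4 the estimated value is 4000 nM, with an expected range of 1200 nM to 13000 nM.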

Compound 4, concentration for 50% growth inhibition: 2490 nM
Compound 4: middle estimate off by 1.6-fold (0.21 log units), on the high side, within the range that was stated.
By their numbers in this assay, from the lowest: compounds 3, 4 and 2 (each within the scatter of the next, the first and the last beyond it); then compound 1.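

Putting 4-chlorophenyl in place of 2,4,5-trichlorophenyl on the amide-type nitrogen gives a 2.0-fold lower number from compound 2 to compound 4 (0.29 log units; within the scatter) in this assay and is the first step shown at this position. Compound 2 and compound 4 cannot be told apart in this assay, so the additional chlorine substituents of the 2,4,5-trichlorophenyl group are not shown to matter here. Nothing available explains this result. On these data alone, what remains open is how this assay would respond to a phenyl group with no chlorine on this nitrogen, or to a phenyl group carrying a methoxy group or an amine.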